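Swapping the thiophene ring for a chlorophenyl group

The source may hold more compounds than are shown below. What is called first, only, known or untested is meant among the compounds shown, and "the series" means these compounds.

Four compounds share one core and differ only in the group on the five-membered ring with two nitrogens and one oxygen. Compound 1 `CC(C)(C)n1ncc(OCc2nnc(-c3ccc(Br)cc3)o2)c(Cl)c1=O` carries 4-bromophenyl there, and in a functional assay on the whole organism for inhibition, with Mythimna separata as the target, with a stated time of 5 days (on this read-out lower numbers stand for an effect already at smaller amounts and higher numbers for an effect only at larger amounts of compound), compound 1 gives 21.4 ug/mL. Compound 2 `Cc1nnc(COc2cnn(C(C)(C)C)c(=O)c2Cl)o1` carries methyl, and in this assay compound 2 gives only a limit, > 300 ug/mL. Compound 3 `CC(C)(C)n1ncc(OCc2nnc(-c3cccs3)o2)c(Cl)c1=O` carries thiophen-2-yl, and in this assay compound 3 also gives only a limit, > 300 ug/mL. Compound 3 therefore sits at the limit of > 300 ug/mL in this assay, at which 2 of the 3 values shown sit. The measured steps are an at least 14-fold higher number from compound 1 to compound 2 (1.14 log units; beyond the scatter) and an at least 14-fold higher number from compound 1 to compound 3 (1.14 log units; beyond the scatter), while a step that the two limits leave unreadable from compound 2 to compound 3. Compound 4 `CC(C)(C)n1ncc(OCc2nnc(-c3ccc(Cl)cc3)o2)c(Cl)c1=O` is not yet measured; the change is 4-chlorophenyl in place of thiophen-2-yl on an aromatic carbon. This change largely reverses the move from compound 1 to compound 3, replacing the thiophen-2-yl group with a halogen-bearing six-membered carbon ring closely resembling the 4-bromophenyl of compound 1. A large drop is therefore expected, an at least 10-fold lower number from compound 3 to compound 4 (1.00 log units; beyond the scatter). Compound 4 is estimated at 30 ug/mL, with a range from 10 ug/mL to 120 ug/mL.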

Compound 4, half-maximal effective concentration: 1.9 ug/mL
For compound 4 the middle estimate is 16-fold (1.20 log units) above the measured one, and the stated range ends above it.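

Putting 4-chlorophenyl on this carbon of the five-membered ring gives an at least 150-fold lower number from compound 3 to compound 4 (2.19 log units; beyond the scatter) and an at least 150-fold lower number from compound 2 to compound 4 (2.19 log units; beyond the scatter). Both of these steps start from a limit and not from a number: the limit of > 300 ug/mL in this assay, at which 2 of the 4 values shown sit.

For the compounds shown here, what the earlier compounds could not show is that the choice of halogen matters and not just the presence of a halogen-bearing six-membered ring: chloro in place of bromo, with the rest of the molecule unchanged, gives an 11-fold lower number from compound 1 to compound 4 (1.05 log units; beyond the scatter).

Going by these compounds, it remains open how plain phenyl, 4-fluorophenyl or 4-methoxyphenyl would read in this place, and so whether a halogen is needed here at all. The data also cannot say why chloro and bromo differ so clearly, or whether the same gap would appear on a shared core carrying another group in place of tert-butyl.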